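The compounds below may be only part of what the source reports. "The series", "measured", "known", "first", "only" and "open" are said of these compounds alone.

Among the measured compounds shown here, compound 2, with the structure `Fc1ccc(-c2cn3ccnc3c(-c3ccc4ncn(C5CCCCC5)c4c3)n2)cc1`, is the most lipophilic of the three compounds measured so far in a physicochemical assay for lipophilicity, using the shake flask method, in phosphate buffer, measured as octanol-water partition, with a stated time of 85 min, at pH 7.4 (a lower number here means a more polar compound, a higher number a more lipophilic compound), where compound 2 gives 2.01. Its nearest neighbour is compound 3, `CCc1ccc(-c2cn3ccnc3c(-c3ccc4ncn(C5CCCCC5)c4c3)n2)cc1`, which in this assay gives 1.66; the furthest is compound 1, `COc1ccc(-c2cn3ccnc3c(-c3ccc4ncn(C5CCCCC5)c4c3)n2)cc1`, which gives 1.41. The steps among them are a number 0.60 log units higher from compound 1 to compound 2 (beyond the scatter), a number 0.25 log units higher from compound 1 to compound 3 (within the scatter) and a number 0.35 log units lower from compound 2 to compound 3 (beyond the scatter).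

Compound 4, `CC(=O)c1ccc(-c2cn3ccnc3c(-c3ccc4ncn(C5CCCCC5)c4c3)n2)cc1`, differs from compound 2 by the change (acetyl in place of fluoro on an aromatic carbon). For the measured compounds named here, two measured steps bear on it. Replacing the fluoro of compound 2 by ethyl gave a number 0.35 log units lower from compound 2 to compound 3 (beyond the scatter), and the reverse of a number 0.60 log units higher from compound 1 to compound 2 (beyond the scatter) shows that exchanging fluoro for methoxy, a group which like acetyl carries 1 hydrogen-bond acceptor, lowered the value by a modest amount. Acetyl therefore is expected to move the number in the same direction, and probably further than methoxy did, because compound 1 already gives 1.41 with a smaller group.

The expected step is a number 0.76 log units lower from compound 2 to compound 4 (beyond the scatter). For compound 4 the estimate in this assay is 1.25, with a range from 0.85 to 1.65.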

Compound 4, partition coefficient: 2.06
Beside the measured number, compound 4's estimate is 0.81 log units below it; the measured number lies above the stated range.
By their numbers in this assay, from the lowest: compounds 1 and 3 (each within the scatter of the next); then compounds 2 and 4 (each within the scatter of the next).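

In this assay the change to 4-acetylphenyl from 4-fluorophenyl, para to a large group, gives a number 0.05 log units higher from compound 2 to compound 4 (within the scatter) and so does not separate acetyl from fluoro, even though acetyl brings more heavy atoms and a hydrogen-bond acceptor. Acetyl does stand apart from the other two groups, with a number 0.40 log units higher from compound 3 to compound 4 (beyond the scatter) and with a number 0.65 log units higher from compound 1 to compound 4 (beyond the scatter) as well, so the four compounds form two sets: compounds 1 and 3 at the lower end, and compounds 2 and 4 at the upper end. Among these compounds neither the heavy-atom count of the group nor a hydrogen-bond acceptor in it sorts the numbers, and compound 4 is the one that goes against both.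

Nothing available accounts for this grouping of the four compounds. As far as these compounds go, it remains open where an amine, a carboxylic acid or a longer alkyl chain at this same place would fall in this assay and whether a larger ketone would stay with acetyl and fluoro.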